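A Change at the Amide Nitrogen: From Compound 2 to Compound 3

This account rests on a few compounds, and the source may have more. Where it says the series, first, only, none or still open, it means among the compounds named here.

Measured so far:
compound 1 `CCOC(=O)C1CCN(C(=O)c2cc(-c3ccc(C)cc3)nn2Cc2ccccc2)CC1`: 54.4%
compound 2 `Cc1ccc(-c2cc(C(=O)NCc3cccnc3)n(Cc3ccccc3)n2)cc1`: 24.4%

In a functional assay on the whole organism (strain Swiss albino) for inhibition, with Mus musculus as the target, read by paw edema, with stated times of 30 min and 270 min, at a dose of 100 mg/kg by the subcutaneous route (on this read-out lower numbers stand for less inhibition and higher numbers for more inhibition at the one dose given (going by the name of the read-out)), compound 1 gives 54.4%, while compound 2 gives 24.4%. Compound 2 therefore stands lowest of the two, and its nearest neighbour, compound 1, lies beyond the usual scatter above it. Compound 3 `Cc1ccc(-c2cc(C(=O)NNc3ccc4ccccc4n3)n(Cc3ccccc3)n2)cc1` has not yet been measured. It differs from compound 2 in one place: (quinolin-2-yl)amino in place of (pyridin-3-yl)methyl on an amide-type nitrogen. Among the measured compounds shown here, no pair of measured compounds shares this kind of change, so there is no measured step to lean on, and the direction of the change remains open. Given that compound 2 gives 24.4%, the room upward is larger than the room downward. The expected step of a number 10.6 percentage points higher from compound 2 to compound 3 (beyond the scatter) is a modest rise, near the edge of the scatter. For compound 3 the estimate is 35%, within 15% to 60%.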

Compound 3, a percentage reported as inhibition, in the whole organism at one dose (the size of the read-out at that dose, not a potency): 44.4%
Beside the measured number, compound 3's estimate is 9.4 percentage points below it, within the range that was stated.
By their numbers in this assay, from the lowest: compound 2; then compounds 3 and 1 (each within the scatter of the next).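

In this assay, among the compounds shown here, the amide-type nitrogen proves to be a place where the read-out responds to a single change: (quinolin-2-yl)amino in place of (pyridin-3-yl)methyl gives a number 20 percentage points higher from compound 2 to compound 3 (beyond the scatter), the first step between compounds that differ in one place. The entering group differs from the leaving one in its heavy atoms, its rings and its hydrogen-bond donors and acceptors all at once, so this one step cannot assign the rise to any one of these. Nothing at hand accounts for the rise.

The compounds shown leave open whether the rise follows the quinoline or the amino link on the amide-type nitrogen. A (quinolin-2-yl)methyl or a (pyridin-3-yl)amino group at this place would separate the two.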